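The source may report more compounds than this note shows. Statements on the series, on what has been measured and on what is new or still open speak of the compounds shown alone.

Of the compounds shown here, three have been measured in a functional assay on Right cardiac atrium for agonist activity at histamine H2 receptor (Cavia porcellus), with a stated time of 30 min, in the presence of a further agent that is not named here; on this read-out higher numbers stand for an effect only at larger amounts of compound and lower numbers for an effect already at smaller amounts. Compound 1 `Cc1nc(N)sc1CCCN/C(N)=N/C(=O)NC(C)c1cccc(F)c1` gives 26.3 nM in this assay, the lowest of the three numbers. Compound 2 `Cc1nc(N)sc1CCCN/C(N)=N/C(=O)NC(c1ccccc1)C(C)C` gives 34.7 nM in this assay, which lies within the scatter of the value of compound 1. Compound 3 `Cc1nc(N)sc1CCCN/C(N)=N/C(=S)N[C@H](C)c1ccccc1` gives 89.1 nM in this assay, a number that sits beyond the scatter above compound 1; compound 3 differs from compound 1 in more than one place, so no single change can be read off that pair.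

Compound 4 `Cc1nc(N)sc1CCCN/C(N)=N/C(=O)NC(C)c1ccccc1F` has not yet been measured. It differs from compound 1 in one place: 2-fluorophenyl in place of 3-fluorophenyl on a saturated chain carbon bound to an amide-type nitrogen and a saturated chain carbon. Among the compounds with values here, no other pair in this set differs in the same way, so there is no measured step to lean on. The expected step is a 1.3-fold higher number from compound 1 to compound 4 (0.12 log units; within the scatter), no larger than the usual scatter, with no firm direction. Compound 4 is accordingly estimated at 35 nM in this assay, with a range from 12 nM to 100 nM.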

Compound 4, half-maximal effective concentration: 12.3 nM
Beside the measured number, compound 4's estimate is 2.8-fold (0.45 log units) above it; measured number inside the range.
By their numbers in this assay, from the lowest: compound 4; then compounds 1 and 2 (each within the scatter of the next); then compound 3.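

With the atom count and composition of the group unchanged, 2-fluorophenyl in place of 3-fluorophenyl on a saturated chain carbon bound to an amide-type nitrogen and a saturated chain carbon gives a 2.1-fold lower number from compound 1 to compound 4 (0.33 log units; beyond the scatter) in this assay. Within the data shown here, this shows that the read-out at this position responds to where the fluorine sits on the phenyl ring, which the earlier compounds could not show, as none of them differed in one place only. The step is modest and rests on a single pair, and nothing measured here accounts for it.

The compounds shown do not tell whether a chlorine or a methoxy group in place of the fluorine would give a similar step. Also open, going by these compounds, is whether the step would carry over to a compound with the isopropyl group of compound 2 in place of the methyl group on that saturated chain carbon.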